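Acetyl on the ring oxygen: a second look

The source may hold more compounds than are shown below. What is called first, only, known or untested is meant among the compounds shown, and "the series" means these compounds.

Going by the values given here, the three compounds measured so far share an amide linking a nitro-bearing thiazole to a hydroxylated benzene ring. Compound 1 has the structure `O=C(Nc1ncc([N+](=O)[O-])s1)c1cc(Cl)cc(Cl)c1O` and, in an ADME assay on HEK-293T cells (Homo sapiens) for cytotoxicity, read by MTT assay, tested at 100 uM (a higher number here means a weaker effect of the compound at the concentration tested, a lower number a stronger effect), compound 1 gives 23.5%. Compound 2, `CC(=O)Oc1c(Cl)cc(Cl)cc1C(=O)Nc1ncc([N+](=O)[O-])s1`, differs from compound 1 only by acetyl in place of hydrogen on an oxygen on an aromatic ring

That single change made a step of a number 71.6 percentage points higher from compound 1 to compound 2 (beyond the scatter), so the acetylated compound 2, at 95.1%, leaves the cells far less affected than compound 1 does. Compound 3, `COc1ccc(O)c(C(=O)Nc2ncc([N+](=O)[O-])s2)c1`, carries a different pattern of substituents on the benzene ring; how the two cores of compound 1 and compound 3 differ is not broken down here. In this assay compound 3 gives 100%, which lies within the scatter of the value of compound 2.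

Compound 4, `COc1ccc(OC(C)=O)c(C(=O)Nc2ncc([N+](=O)[O-])s2)c1`, has not yet been measured. It differs from compound 3 by acetyl in place of hydrogen on an oxygen on an aromatic ring

Among the compounds with values here, this is the same change as the one from compound 1 to compound 2, at the same kind of place. The earlier step was large, but compound 3 already sits at the top of the range that this readout can report, so compound 4 is expected to make only a small step of a number 2 percentage points lower from compound 3 to compound 4 (within the scatter), because the value of compound 3 in this assay is 100% and leaves little room to rise. The expected value of compound 4 is therefore 98%, with a likely range from 85% to 100%.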

Compound 4, a percentage reported as activity, at one concentration (the size of the read-out at that concentration, not a potency): 94.1%
Estimate against measurement, compound 4: 3.9 percentage points above; measured number inside the range.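

In this assay, replacing hydroxy with acetoxy on the core of compound 3 gives a number 5.9 percentage points lower from compound 3 to compound 4 (within the scatter), so on this core the change has no effect that can be told apart from the scatter. The same change therefore does not carry over from one core to the other with the same size, and a step seen on the core of compound 1 cannot be assumed on the core of compound 3: the same change on two cores in this assay, a number 71.6 percentage points higher (beyond the scatter) from compound 1 to compound 2 and a number 5.9 percentage points lower (within the scatter) from compound 3 to compound 4, 77.5 percentage points apart, beyond the scatter of two such steps. This shows that, in these two pairs, the outcome of adding the acetyl depends on the core that carries it, but it does not show which difference between the cores matters or what would happen on a third core, and compound 3, at 100%, leaves little room for any rise to appear.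

The compounds shown leave open whether the two chlorine atoms of compound 1 or the methoxy group of compound 3 accounts for the different outcomes, since the two cores differ in more than one place. They also leave open how other groups on the same oxygen would behave, such as a longer butanoyl chain or a carbamate.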